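Hydrazide series on gastric cells: chloro position change

The compounds below may be only part of what the source reports. "The series", "measured", "known", "first", "only" and "open" are said of these compounds alone.

Compound 1 `O=C(NNC(=O)c1ccccc1Cl)c1ccc(NS(=O)(=O)c2cnc(O)nc2O)cc1` and compound 3 `O=C(NNC(=O)c1ccccc1NS(=O)(=O)c1cnc(O)nc1O)c1ccccc1Cl` share the hydrazide and sulfonamide parts; the difference between the two cores is not broken down here. Compound 2 `O=C(NNC(=O)c1cccc(Cl)c1)c1ccc(NS(=O)(=O)c2cnc(O)nc2O)cc1` is derived from compound 1, and compound 4 `O=C(NNC(=O)c1ccccc1NS(=O)(=O)c1cnc(O)nc1O)c1cccc(Cl)c1` from compound 3, each by the same change.

In a functional assay on SGC-7901 cells (Homo sapiens) for antiproliferative activity, read by MTT assay, with a stated time of 24 h (on this read-out lower numbers stand for stronger inhibition and higher numbers for weaker inhibition), compound 1 gives 3240 nM. Compound 2 gives 8610 nM, and compound 3 gives 2410 nM. Compound 3 and compound 1 sit within the scatter of each other; compound 3 against compound 2 lies beyond it.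

For the measured compounds named here, the one measured step is 3-chlorophenyl in place of 2-chlorophenyl on a carbonyl carbon and produced a 2.7-fold higher number from compound 1 to compound 2 (0.42 log units; beyond the scatter). Going by the values given here, the change 3-chlorophenyl in place of 2-chlorophenyl on a carbonyl carbon is the same change on the core of compound 3, and only one instance of it has been measured, so the carry-over rests on a single pair.

For compound 4 a step of a 2.7-fold higher number from compound 3 to compound 4 (0.43 log units; beyond the scatter) is expected, because compound 1 to compound 2 gave a 2.7-fold higher number from compound 1 to compound 2 (0.42 log units; beyond the scatter). Compound 4 is therefore estimated at 6500 nM, most likely between 3000 nM and 14000 nM.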

Compound 4, half-maximal inhibitory concentration: 1820 nM
Compound 4: the middle estimate sits 3.6-fold (0.55 log units) above what was measured, and the stated range ends above it.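

In this assay, 3-chlorophenyl in place of 2-chlorophenyl on a carbonyl carbon gave a 1.3-fold lower number from compound 3 to compound 4 (0.12 log units; within the scatter), so the step seen on the core of compound 1 did not recur on the core of compound 3. Read side by side, the two instances of the change disagree: the same change on two cores in this assay, a 2.7-fold higher number (0.42 log units; beyond the scatter) from compound 1 to compound 2 and a 1.3-fold lower number (0.12 log units; within the scatter) from compound 3 to compound 4, 3.5-fold (0.55 log units) apart, beyond the scatter of two such steps

This shows that, across these two pairs, a step measured on one core cannot be carried over to the other, and that on the core of compound 3 no order can be claimed between the 2-chlorophenyl and 3-chlorophenyl compounds; it does not show why the cores differ, nor does it give a rule for any further core, since it rests on two pairs only.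

Still open, on these data alone, is how a plain phenyl or a methoxyphenyl on the same carbonyl carbon would behave on each core. As far as these compounds go, it is equally open whether such groups would give steps that agree between the two cores or diverge as the chlorophenyl pairs do.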